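The compounds below may be only part of what the source reports. "The series", "measured", "known", "first", "only" and "open" are said of these compounds alone.

Compound 1 `O=S(=O)(Nc1ccc2oc(-c3ccccc3)nc2c1)c1ccc(Cl)cc1` is examined in an assay on cells for inhibition of HSP60/HSP10 (Homo sapiens), with a stated time of 60 min; a higher number here means a weaker inhibitor, a lower number a stronger inhibitor. In this assay compound 1 gives > 100000 nM, which is a limit of the assay rather than a number. Compound 2 `O=S(=O)(Nc1ccc2oc(-c3ccccc3)nc2c1)c1ccc(Cl)c(C(F)(F)F)c1` gives > 100000 nM in this assay, likewise a limit. Compound 3 `O=S(=O)(Nc1ccc2oc(-c3ccccc3)nc2c1)c1ccc(C(F)(F)F)cc1` gives > 100000 nM in this assay, again a limit. The step that the two limits leave unreadable from compound 1 to compound 2 and the step that the two limits leave unreadable from compound 1 to compound 3 cannot be read because of the limit of > 100000 nM in this assay, at which 3 of the 3 values shown sit. Compound 1 thus stands only at the limit, and nothing shows whether its true value lies close to that limit or far beyond it.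

Compound 4 `CS(=O)(=O)Nc1ccc2oc(-c3ccccc3)nc2c1` differs from compound 1 in one place: methyl in place of 4-chlorophenyl on a sulfonyl sulfur. For the measured compounds named here, no measured step bears directly on this change; the two measured steps concern substituents on the aromatic ring that is removed here, and both are unreadable. For compound 4 in this assay the outcome is expected to be 150000 nM, within a range from 50000 nM to 1000000 nM. The step that the limit leaves unreadable from compound 1 to compound 4 is therefore expected to be none beyond the scatter, and the assay is most likely to report only its limit again for compound 4.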

Compound 4, half-maximal inhibitory concentration: > 100000 nM
Compound 4: no number, only a limit; the forecaster's own chance of this, stated with the estimate: 85%; the middle value does not contradict the limit.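

Like compounds 1, 2 and 3, compound 4 gives only a limit, so the step from compound 1 to compound 4 cannot be read, because all the values sit at that same limit: the limit of > 100000 nM in this assay, at which 4 of the 4 values shown sit. The compounds shown leave open whether any change to the shared core would yield a measurable value.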